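This account rests on a few compounds, and the source may have more. Where it says the series, first, only, none or still open, it means among the compounds named here.

Two compounds share one core and differ only in the group on a sulfonyl sulfur. Compound 1 `Cc1ccc2ncc(S(=O)(=O)c3cc(Cl)cc(Cl)c3)c(N3CCC(C)CC3)c2c1` carries a 3,5-dichlorophenyl, and in an assay on isolated protein for displacement of a labelled ligand from metabotropic glutamate receptor 5 (Homo sapiens), with a stated time of 60 min, tested at 1 uM (on this read-out lower numbers stand for less inhibition and higher numbers for more inhibition at the one concentration tested (going by the name of the read-out)), compound 1 gives 75%. Compound 2 `Cc1ccc2ncc(S(=O)(=O)c3ccc(Cl)c(Cl)c3)c(N3CCC(C)CC3)c2c1` carries a 3,4-dichlorophenyl, and in this assay compound 2 gives 82%. Going by the values given here, the one measured step, a number 7 percentage points higher from compound 1 to compound 2 (within the scatter), is within the scatter. Compound 2 stands highest of the two numbers, but its nearest neighbour, compound 1, lies within the scatter of it, so no order between the two can be claimed.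

Compound 3 `Cc1ccc2ncc(S(=O)(=O)c3cccc(C#N)c3)c(N3CCC(C)CC3)c2c1` has not yet been measured. It differs from compound 2 in one place: 3-cyanophenyl in place of 3,4-dichlorophenyl on a sulfonyl sulfur. Among the compounds with values here, the only measured step concerned one dichlorophenyl replacing another, and bears on the new step only in showing that the group on the sulfonyl sulfur could be rearranged without a shift beyond the scatter. Within the data shown here, no measured step exchanges a chlorinated ring for a ring bearing a nitrile, so there is little to go on. The expected step is a number 27 percentage points lower from compound 2 to compound 3 (beyond the scatter), a fall in this assay, with wide uncertainty. Compound 3 is estimated at 55%, between 25% and 85%.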

Compound 3, a percentage reported as inhibition, at one concentration (the size of the read-out at that concentration, not a potency): 52%
Estimate against measurement, compound 3: 3 percentage points above, within the range that was stated.
By their numbers in this assay, from the lowest: compound 3; then compounds 1 and 2 (each within the scatter of the next).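

Exchanging either dichlorophenyl for 3-cyanophenyl on a sulfonyl sulfur moves the number in this assay beyond the scatter, with a number 30 percentage points lower from compound 2 to compound 3 (beyond the scatter) and a number 23 percentage points lower from compound 1 to compound 3 (beyond the scatter). The earlier pair showed only that moving one chlorine on the ring gave no readable difference, whereas this change, which removes both chlorines and brings in a nitrile, gives a readable fall, and it does so with the same number of heavy atoms leaving and entering. Compound 3 therefore sits apart from the other two, but no measurement here explains the fall.

This single exchange removes the chlorines and adds the nitrile together, so the compounds shown cannot say which of the two matters, or whether both do. As far as these compounds go, a plain phenyl or a phenyl carrying one chlorine on the sulfonyl sulfur would help separate the two parts of the change, and since each number is a reading at one concentration, the size of any difference in potency also stays open.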